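The source may hold more compounds than are shown below. What is called first, only, known or untested is meant among the compounds shown, and "the series" means these compounds.

Of the compounds shown here, two have been tested in a functional assay on Jurkat cells (Homo sapiens) for activation, with a stated time of 24 h; on this read-out higher numbers stand for an effect only at larger amounts of compound and lower numbers for an effect already at smaller amounts. Compound 1 `Oc1ccccc1CNc1ccc(N2CCCC2)cc1` in this assay gives "not active" (no number reported), so no number is available for it. Within the data shown here, compound 2 `Oc1ccccc1CNc1ccc(-c2ccc(F)cc2)cc1` in this assay gives 3860 nM, the only number reported so far, which makes compound 2 the single point of reference here. Compound 3 `Oc1cccc(-c2ccc(NCc3ccccc3O)cc2)c1` is the next compound to be measured. It differs from compound 2 in one place: 3-hydroxyphenyl in place of 4-fluorophenyl on an aromatic carbon. Among the measured compounds shown here, the second aromatic ring of compound 2 is kept, and no pair of measured compounds shows how such a change plays out, so the step in this assay is expected to be small, not clearly beyond the scatter, and with no firm direction: a 1.3-fold lower number from compound 2 to compound 3 (0.11 log units; within the scatter). Compound 3 is therefore expected to give about 3000 nM in this assay, most likely between 800 nM and 12000 nM.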

Compound 3, half-maximal effective concentration: "not active" (no number reported)
Nothing numeric was reported for compound 3, and the estimate cannot be compared.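

Among these compounds, compound 3 gives no number in this assay, so no step from compound 2 to compound 3 can be read. The compounds shown leave open how changing the group on the second aromatic ring moves this read-out. No measurement at hand offers an explanation for the result.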